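Lengthening the Chain on the Shared Core

This account rests on a few compounds, and the source may have more. Where it says the series, first, only, none or still open, it means among the compounds named here.

Compound 3 `CCCc1cc(C(=O)N[C@H](C)CCCc2cccnc2)ccc1-c1ccc(OC)c(OC)c1` gives 50 nM in an assay (Canis lupus familiaris) for binding affinity to platelet-activating factor receptor (Homo sapiens), read by radioligand binding (on this read-out lower numbers stand for stronger inhibition and higher numbers for weaker inhibition), the lowest of the three numbers measured, though it sits within the scatter of compound 1. Compound 1 `C=CCc1cc(C(=O)N[C@H](C)CCCc2cccnc2)ccc1-c1ccc(OC)c(OC)c1` gives 80 nM. Compound 2 `COc1ccc(-c2ccc(C(=O)NCCCCc3cccnc3)cc2[N+](=O)[O-])cc1OC` gives 200 nM, and its gap from compound 3 lies beyond the scatter. Compound 4 `CCCCc1cc(C(=O)N[C@H](C)CCCc2cccnc2)ccc1-c1ccc(OC)c(OC)c1` has not yet been measured. It differs from compound 3 by methyl in place of hydrogen on a saturated chain carbon, three bonds along the chain from an aromatic carbon; cut one bond further out, the change reads as propyl to butyl. Within the data shown here, the only measured step at this part of the shared core is a 1.6-fold lower number from compound 1 to compound 3 (0.20 log units; within the scatter), which lies within the scatter. Among the measured compounds shown here, no measured step shows what adding one more carbon to this chain does, so the expectation rests on compound 3 alone. Compound 4 is therefore expected to land close by, with an estimated step of a 1.1-fold lower number from compound 3 to compound 4 (0.05 log units; within the scatter). Compound 4 is estimated at 45 nM, expected to fall between 18 nM and 110 nM.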

Compound 4, half-maximal inhibitory concentration: 4 nM
Estimate against measurement, compound 4: 11-fold (1.05 log units) above; the measured number lies below the stated range.
By their numbers in this assay, from the lowest: compound 4; then compounds 3 and 1 (each within the scatter of the next); then compound 2.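

Among these compounds, on the shared core, the chain carbon three bonds along from an aromatic carbon turns out to matter a great deal: in this assay, the change of propyl to butyl gives a 13-fold lower number from compound 3 to compound 4 (1.10 log units; beyond the scatter), whereas no earlier step at this part of the core went beyond the scatter. Read against the vinyl-bearing compound, the butyl chain gives a 20-fold lower number from compound 1 to compound 4 (1.30 log units; beyond the scatter), so one added methyl sets compound 4 apart from two compounds that lie within the scatter of each other. Nothing available explains why this single carbon counts for so much.

From the compounds shown here alone, whether the gain continues with a longer chain such as pentyl or hexyl remains open, as does whether a branched chain or a chain ending in a hydroxyl or an amine would keep it. Compound 2 differs from the others in more than one place, so it cannot show what a butyl chain would do alongside its nitro group.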